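Aryl amide variation on a shared core, three measured analogues

This account rests on a few compounds, and the source may have more. Where it says the series, first, only, none or still open, it means among the compounds named here.

Measured so far in a functional assay on 143B cells (Homo sapiens) for antiproliferative activity, read by MTT assay, with a stated time of 48 h; a higher number here means a weaker inhibitor, a lower number a stronger inhibitor:
- compound 1, `O=C(/C=C/c1cccc(NC(=O)c2ccccc2Br)c1)c1nc2ccccc2[nH]1`, gives 6050 nM
- compound 2, `O=C(Nc1cccc(/C=C/C(=O)c2nc3ccccc3[nH]2)c1)c1cccc(Br)c1`, gives 4620 nM
- compound 3, `Cc1ccc(C(=O)Nc2cccc(/C=C/C(=O)c3nc4ccccc4[nH]3)c2)cc1`, gives 6560 nM

Compound 3 carries the highest of the three numbers, but only by margins inside the scatter: a 1.1-fold higher number from compound 1 to compound 3 (0.04 log units; within the scatter) and a 1.4-fold higher number from compound 2 to compound 3 (0.15 log units; within the scatter). The three measured compounds therefore read as one level in this assay, with no order among them.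

Compound 4, `Cc1cc(C)cc(C(=O)Nc2cccc(/C=C/C(=O)c3nc4ccccc4[nH]3)c2)c1`, is not yet measured. Its change from compound 3 is 3,5-dimethylphenyl in place of 4-methylphenyl on a carbonyl carbon. Every measured step in the series alters the same aryl group on that carbonyl carbon: a 1.3-fold lower number from compound 1 to compound 2 (0.12 log units; within the scatter), a 1.1-fold higher number from compound 1 to compound 3 (0.04 log units; within the scatter), a 1.4-fold higher number from compound 2 to compound 3 (0.15 log units; within the scatter). All three are within the scatter, so exchanges at this position have so far left this assay unmoved. Adding a second methyl at a different place on the same ring is not covered by any step shown, so the expectation rests on the flat trend alone.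

For compound 4 the expected step is a 1.0-fold lower number from compound 3 to compound 4 (0.00 log units; within the scatter), no shift beyond the scatter. The estimate for compound 4 in this assay is 6500 nM, within 3200 nM to 13000 nM.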

Compound 4, half-maximal inhibitory concentration: 4020 nM
Beside the measured number, compound 4's estimate is 1.6-fold (0.21 log units) above it, within the range that was stated.
By their numbers in this assay, from the lowest: compounds 4, 2, 1 and 3 (each within the scatter of the next).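

Among the compounds shown here, the 3,5-dimethylphenyl group is the first aryl group here with two methyl substituents, and it still leaves this assay flat: a 1.6-fold lower number from compound 3 to compound 4 (0.21 log units; within the scatter) and a 1.1-fold lower number from compound 2 to compound 4 (0.06 log units; within the scatter) and a 1.5-fold lower number from compound 1 to compound 4 (0.18 log units; within the scatter). With 2-bromophenyl, 3-bromophenyl, 4-methylphenyl and 3,5-dimethylphenyl all on the carbonyl carbon, the four compounds form one level, so a change in the number of ring substituents has joined changes in their kind and place without any step beyond the scatter. Nothing at hand explains this flatness.

As far as these compounds go, all four groups are carbon-only aromatic rings carrying bromine or methyl, so the effect of an amine or a carboxylic acid on that ring remains open. Also open, from the compounds shown here alone, is whether a longer chain in place of the ring would move the number in this assay.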